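Removing the acetyl from an inactive pyran compound

The source may report more compounds than this note shows. Statements on the series, on what has been measured and on what is new or still open speak of the compounds shown alone.

Measured compounds:
compound 1, `CN1CC(O)C(O)C(O)C1CO`, gives 5300000 nM
compound 2, `CC(=O)C1C(O)C=COC1c1ccccc1`, gives > 100000000 nM

Compound 1 `CN1CC(O)C(O)C(O)C1CO` was tested in an assay on isolated protein for inhibition of tissue alpha-L-fucosidase (Homo sapiens) (a lower number here means a stronger inhibitor, a higher number a weaker inhibitor), where compound 1 gives 5300000 nM, a weak inhibition. Compound 2 `CC(=O)C1C(O)C=COC1c1ccccc1` belongs to a different structural family. In this assay compound 2 gives > 100000000 nM, which is a limit of the assay and not a number. Compound 2 therefore stands at the limit of > 100000000 nM in this assay, at which 1 of the 2 values shown sits, so its standing is known only as that limit, with no measured number to compare against compound 1.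

Compound 3 `OC1C=COC(c2ccccc2)C1` has not yet been measured. It differs from compound 2 by hydrogen in place of acetyl on a saturated ring carbon. For the measured compounds named here, no pair of measured compounds separated by a single change is available here, so the expected size of this step can rest only on where compound 2 stands. Because compound 2 sits at the limit of > 100000000 nM in this assay, at which 1 of the 2 values shown sits, the step from compound 2 to compound 3 is expected to be a step that the limit leaves unreadable from compound 2 to compound 3, that is, nothing beyond the usual scatter, most probably ending again at the limit. Compound 3 is estimated at 150000000 nM, within a range from 40000000 nM to 600000000 nM.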

Compound 3, inhibition constant: > 100000000 nM
Compound 3 was reported as a limit; the forecaster's own chance of this, stated with the estimate: 80%; the middle value does not contradict the limit.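

Compound 2 and compound 3 both stand at a limit of this assay and not at a measured number, so the step between them cannot be read: the limit of > 100000000 nM in this assay, at which 2 of the 3 values shown sit. From the compounds shown here alone, whether hydrogen in place of acetyl on a saturated ring carbon changes the inhibition at all remains open.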